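An amide swap from compound 2 to compound 4

A few compounds are considered here, and "the series" means these few. Any claim that something is new, unique, unknown or untested is made for them only; others in the source may bear on it.

Values so far in a physicochemical assay for lipophilicity, at pH 7.4 (on this read-out higher numbers stand for higher lipophilicity and lower numbers for lower lipophilicity), are these:
- compound 1 `CNC(=O)c1cc(C(=O)N[C@H]2[C@@H]3COC[C@@H]32)cc2c1OC[C@H]2c1cccc(OC)c1` gives 3.2
- compound 2 `CNC(=O)c1cc(C(=O)N[C@H]2[C@@H]3COC[C@@H]32)cc2c1OC[C@H]2c1ccccc1` gives 3.3
- compound 3 `CNC(=O)c1cc(C(=O)N[C@H]2[C@@H]3COC[C@@H]32)cc2c1OC[C@H]2c1ccncc1` gives 1.3

Compound 2 shares the upper end of these values with compound 1 (a number 0.10 log units higher from compound 1 to compound 2 (within the scatter)), and the clear gap lies downward (a number 2.00 log units lower from compound 2 to compound 3 (beyond the scatter)). Compound 4 `CNC(=O)c1cc(C(=O)Nc2cnn(C)c2)cc2c1OC[C@H]2c1ccccc1` is still unmeasured and departs from compound 2 at one place (a group of 6 heavy atoms (4 carbon, 2 nitrogen; one five-membered aromatic ring with 2 hetero atoms) in place of a group of 6 heavy atoms (5 carbon, 1 oxygen; one three-membered non-aromatic ring of carbon only, one five-membered non-aromatic ring with 1 hetero atom), on an amide-type nitrogen). Among the measured compounds shown here, the large steps (a number 1.90 log units lower from compound 1 to compound 3 (beyond the scatter)) and (a number 2.00 log units lower from compound 2 to compound 3 (beyond the scatter)) both concern a saturated ring carbon, so no measured step covers this place. No change beyond the scatter is therefore expected, but those large steps argue for a wide range. An expected no change at the digits printed from compound 2 to compound 4 (within the scatter) would lie within the scatter. For compound 4 the estimated value is 3.3 (expected range 2.7 to 3.9).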

Compound 4, distribution coefficient: 3.5
Compound 4: the middle estimate sits 0.20 log units below what was measured, and the stated range covers the measured number.
By their numbers in this assay, from the lowest: compound 3; then compounds 1, 2 and 4 (each within the scatter of the next).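

In this assay, 1-methyl-1H-pyrazol-4-yl on the amide-type nitrogen gives a number 0.20 log units higher from compound 2 to compound 4 (within the scatter). This is the only step shown at this place, and it shows that a five-membered aromatic ring can stand in for the group with three-membered and five-membered non-aromatic rings without a change beyond the scatter. Nothing available explains this outcome.

Going by these compounds, whether a group carrying an amine or a carboxylic acid would behave alike on this nitrogen remains open. So does whether pyridin-4-yl on the saturated ring carbon would give a similarly large step alongside 1-methyl-1H-pyrazol-4-yl.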